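Nitro added to a weak biaryl ether scaffold

A few compounds are considered here, and "the series" means these few. Any claim that something is new, unique, unknown or untested is made for them only; others in the source may bear on it.

Of the compounds shown here, three have so far been tested in an assay on COS-7 cells for inhibition of patatin-like phospholipase domain-containing protein 2 (Mus musculus); on this read-out lower numbers stand for stronger inhibition and higher numbers for weaker inhibition. Compound 1, `CCOC(=O)c1cncc(-c2ccc(OCC)cc2)c1`, carries an ester on a pyridine-type core and gives 130000 nM. Compound 2, `CCOC(=O)C1CCCC(c2ccc(OCC)cc2)N1`, has a saturated ring in place of that core; in this assay compound 2 reaches only the limit of > 200000 nM, which is a boundary of the measurement rather than a number. Compound 3, `CCOc1ccc(-c2ccccc2)cc1`, is the simplest of the set, a two-ring system with an ethoxy group. In this assay compound 3 likewise stops at the limit of > 200000 nM, again a boundary and not a measured value. So compound 3 stands at the weak end of what this assay can report, and the limit of > 200000 nM in this assay, at which 2 of the 3 values shown sit, shows that it shares this position with another compound.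

Compound 4, `CCOc1ccc(-c2cccc([N+](=O)[O-])c2)cc1`, differs from compound 3 by nitro in place of hydrogen on an aromatic carbon, placed on an aromatic carbon of a six-membered aromatic ring of carbon only. Within the data shown here, no measured pair in this set mirrors such a change, so there is no direct guide. The expected step is a number no higher from compound 3 to compound 4 (the limit leaves the size open), none beyond the usual scatter, since the starting point is already a limit. Compound 4 is therefore estimated at 200000 nM, with a range from 60000 nM to 600000 nM, and it may well return only a limit again.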

Compound 4, half-maximal inhibitory concentration: > 200000 nM
Compound 4: no number, only a limit; the forecaster's own chance of this, stated with the estimate: 60%; the middle value sits exactly at the limit.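

Compound 3 and compound 4 both give only a limit in this assay, so no step between them can be read, and both sit at the boundary shared by most of the set: the limit of > 200000 nM in this assay, at which 3 of the 4 values shown sit.

The compounds shown leave open whether nitro in place of hydrogen on an aromatic carbon changes inhibition at all.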